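Methoxy for Fluoro on One Phenyl Ring

This account rests on a few compounds, and the source may have more. Where it says the series, first, only, none or still open, it means among the compounds named here.

Measured in a functional assay on HeLa cells (Homo sapiens) for cytotoxicity, read by MTT assay, with a stated time of 2 days; on this read-out lower numbers stand for higher toxicity in this test and higher numbers for lower toxicity in this test:
compound 1 `CC(=O)c1cc(-c2ccccc2)cc2cc(-c3ccccc3)[nH]c12` gives > 100000 nM
compound 2 `CC(=O)c1cc(-c2ccccc2)cc2cc(-c3ccc(F)cc3)[nH]c12` gives > 100000 nM
compound 3 `CC(=O)c1cc(-c2ccc(F)cc2)cc2cc(-c3ccc(F)cc3)[nH]c12` gives 13800 nM

The value of compound 1 is a limit of the assay, not a number. The value of compound 2 is likewise only a limit, so it cannot be placed more closely than that; it sits at the limit of > 100000 nM in this assay, at which 2 of the 3 values shown sit. Compound 4 `COc1ccc(-c2cc3cc(-c4ccccc4)cc(C(C)=O)c3[nH]2)cc1` differs from compound 2 in one place: methoxy in place of fluoro on an aromatic carbon. Of the measured steps, a step that the two limits leave unreadable from compound 1 to compound 2 cannot be read, and an at least 7.2-fold lower number from compound 2 to compound 3 (0.86 log units; beyond the scatter) concerns fluoro entering on the other phenyl ring, so neither step mirrors this exchange. Within the data shown here, with no matching step to lean on, compound 4 is expected to stay near the same limit, and the step of a number no higher from compound 2 to compound 4 (the limit leaves the size open) is estimated to fall within the scatter. The estimate for compound 4 in this assay is 100000 nM, ranging from 30000 nM to 300000 nM.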

Compound 4, concentration lethal to 50% of the cells: 18900 nM
Beside the measured number, compound 4's estimate is 5.3-fold (0.72 log units) above it, and the stated range ends above it.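

In this assay, among these compounds, the exchange of 4-fluorophenyl for 4-methoxyphenyl gives the first readable change at this position, with an at least 5.2-fold lower number from compound 2 to compound 4 (0.72 log units; beyond the scatter). Methoxy in place of hydrogen brings an at least 5.2-fold lower number from compound 1 to compound 4 (0.72 log units; beyond the scatter), so this place on the ring does respond to a substituent, although the step from hydrogen to fluoro there cannot be read. Compound 2 gives only a limit of the assay: the limit of > 100000 nM in this assay, at which 2 of the 4 values shown sit.

The compounds shown leave open whether an amine or an ethoxy group at this position would lower the number further. They also leave open how methoxy would act on the other phenyl ring.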